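Truncating the piperazine tail of compound 3

The source may hold more compounds than are shown below. What is called first, only, known or untested is meant among the compounds shown, and "the series" means these compounds.

Compound 1 `COc1ncc(-c2ccc3nc(NC(=O)N(C)C)nn3c2)cc1NS(=O)(=O)c1ccc(F)cc1` gives 1780 nM in a functional assay on U-87MG ATCC cells for cytotoxicity against U-87 MG (Homo sapiens), read by MTT assay, with a stated time of 72 h; a lower number here means a stronger inhibitor, a higher number a weaker inhibitor. Compound 2 `CNC(=O)Nc1nc2ccc(-c3cnc(OC)c(NS(=O)(=O)c4ccc(F)cc4)c3)cn2n1` gives 640 nM. Compound 3 `COc1ncc(-c2ccc3nc(NC(=O)NCCN4CCN(C)CC4)nn3c2)cc1NS(=O)(=O)c1ccc(F)cc1` gives 760 nM.

Compound 3 stands second highest of the three; its nearest neighbour is compound 2, and that gap is within the scatter, while compound 1 lies further off: a 2.3-fold lower number from compound 1 to compound 3 (0.37 log units; beyond the scatter). Compound 4 `COc1ncc(-c2ccc3nc(NC(=O)NCCN(C)C)nn3c2)cc1NS(=O)(=O)c1ccc(F)cc1` differs from compound 3 by dimethylamino in place of 4-methylpiperazin-1-yl on a saturated chain carbon, two bonds along the chain from an amide-type nitrogen. The step that bears on this is a 1.2-fold higher number from compound 2 to compound 3 (0.07 log units; within the scatter), which shows that the tail on the urea chain hardly moved the number. Compound 4 is therefore expected to sit near compound 3, with a 1.1-fold lower number from compound 3 to compound 4 (0.04 log units; within the scatter), and its estimated value is 700 nM, within 350 nM to 1400 nM.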

Compound 4, half-maximal inhibitory concentration: 980 nM
Beside the measured number, compound 4's estimate is 1.4-fold (0.15 log units) below it; the measured number falls inside the stated range.
By their numbers in this assay, from the lowest: compounds 2, 3, 4 and 1 (each within the scatter of the next, the first and the last beyond it).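

In this assay, dimethylamino in place of 4-methylpiperazin-1-yl at this chain carbon gives a 1.3-fold higher number from compound 3 to compound 4 (0.11 log units; within the scatter), so between these two compounds the ring makes no readable difference. The shorter tail also stays within the scatter of the hydrogen-bearing urea, with a 1.5-fold higher number from compound 2 to compound 4 (0.19 log units; within the scatter), and a 1.8-fold lower number from compound 1 to compound 4 (0.26 log units; within the scatter) is likewise within the scatter, unlike the step from compound 1 to compound 3. No evidence here accounts for these small steps.

On these data alone, it remains open whether a morpholine, a carboxylic acid or a longer chain at this position would leave the number equally unchanged.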